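The compounds below may be only part of what the source reports. "The series", "measured", "known", "first", "only" and "open" are said of these compounds alone.

Compounds 1, 2 and 3 share one core and differ only in the substituent on it: compound 1 `COc1cccc2c(=O)cc(/C=C/[S+](C)[O-])oc12`, compound 2 `CC(C)C(=O)Oc1ccc2oc(/C=C/[S+](C)[O-])cc(=O)c2c1` and compound 3 `COc1ccc2c(=O)cc(/C=C/[S+](C)[O-])oc2c1`. In a functional assay on A549 cells (Homo sapiens) for cytotoxicity, with a stated time of 48 h (on this read-out higher numbers stand for weaker inhibition and lower numbers for stronger inhibition), compound 1 gives 2200 nM, compound 2 gives 2400 nM and compound 3 gives 2200 nM. Compound 2 has the highest of the three numbers, yet its gaps to compound 1 and to compound 3 both lie within the scatter, so no order among the three is supported. Compound 4 `CCCCCOc1ccc2oc(/C=C/[S+](C)[O-])cc(=O)c2c1` has not been measured. It differs from compound 2 by pentyl in place of isopropylcarbonyl on an oxygen on an aromatic ring. Going by the values given here, no measured step of this kind exists in the set. The step of a 1.1-fold lower number from compound 2 to compound 4 (0.04 log units; within the scatter) is expected to stay within the scatter, in no clear direction. Compound 4 is therefore estimated at 2200 nM, with a range from 800 nM to 6000 nM.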

Compound 4, half-maximal inhibitory concentration: 1600 nM
The estimate for compound 4 lay 1.4-fold (0.14 log units) above the measured number; measured number inside the range.
By their numbers in this assay, from the lowest: compounds 4, 1, 3 and 2 (each within the scatter of the next).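

Replacing isopropylcarbonyl with pentyl on the oxygen on the aromatic ring gives a 1.5-fold lower number from compound 2 to compound 4 (0.18 log units; within the scatter) in this assay. The carbonyl and its hydrogen-bond acceptor can therefore go from this position without the number leaving the scatter. The earlier compounds shown here showed only that methoxy and (isopropylcarbonyl)oxy compounds gave similar numbers across different places on the shared core, not a single change at this place.

From the compounds shown here alone, whether a longer chain, a terminal amine or a carboxylic acid on this oxygen would shift the number beyond the scatter remains open. Nothing at hand explains why the number holds across this change.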